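The source may report more compounds than this note shows. Statements on the series, on what has been measured and on what is new or still open speak of the compounds shown alone.

Three compounds share one core and have been run in the same assay. Compound 1 `CCCCOC(=O)Nc1ccc([Se]C#N)cc1` gives 43400 nM in a functional assay on HTB-54 cells (Homo sapiens) for cytotoxicity, read by MTT assay, with a stated time of 72 h; a higher number here means a weaker inhibitor of growth, a lower number a stronger inhibitor of growth. Compound 2 `C=CCOC(=O)Nc1ccc([Se]C#N)cc1` gives 50100 nM in this assay, and compound 3 `N#C[Se]c1ccc(NC(=O)Oc2ccc(Cl)cc2)cc1` gives 41400 nM in this assay. Compound 2 gives the highest of the three numbers, though its gaps to compound 1 and to compound 3 both fall within the scatter, so the three cannot be told apart on these data. For the measured compounds named here, the one measured step at the saturated chain carbon bound to an oxygen next to a carbonyl group, a 1.2-fold higher number from compound 1 to compound 2 (0.06 log units; within the scatter), also lies within the scatter.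

Compound 4 `CCOC(=O)Nc1ccc([Se]C#N)cc1` has not yet been measured in this assay. It differs from compound 2 by methyl in place of vinyl on a saturated chain carbon bound to an oxygen next to a carbonyl group. Going by the values given here, the only measured step that bears on this is the one from compound 1 to compound 2 at the same place, which exchanged one group for another there and stayed within the scatter. No step beyond the scatter in this assay is therefore expected, in either direction. The expected step is a 1.0-fold lower number from compound 2 to compound 4 (0.02 log units; within the scatter). Compound 4 is estimated to give about 48000 nM in this assay, with an expected range from 24000 nM to 96000 nM.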

Compound 4, concentration for total growth inhibition: 49300 nM
The estimate for compound 4 lay 1.0-fold (0.01 log units) below the measured number; the measured number falls inside the stated range.
By their numbers in this assay, from the lowest: compounds 3, 1, 4 and 2 (each within the scatter of the next).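

At the saturated chain carbon bound to an oxygen next to a carbonyl group, a second exchange now stands beside the first: in this assay, methyl in place of vinyl gives a 1.0-fold lower number from compound 2 to compound 4 (0.01 log units; within the scatter) and so adds allyl to ethyl to the exchanges at this place that stay inside the scatter. The chain can now also be read one carbon further out, where hydrogen in place of ethyl on a saturated chain carbon, two bonds along the chain from an oxygen next to a carbonyl group, gives a 1.1-fold higher number from compound 1 to compound 4 (0.06 log units; within the scatter) and leaves compound 1, compound 2 and compound 4 indistinguishable in this assay across these chains, with or without a double bond outside aromatic rings. No measurement is available that would account for this flat response.

Still open, as far as these compounds go, is what a terminal amine, a carboxylic acid or a much longer chain at this place would give in this assay. From the compounds shown here alone, every step read so far lies within the scatter, and it remains unknown whether any exchange at this place can move the number beyond it.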